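A few compounds are considered here, and "the series" means these few. Any claim that something is new, unique, unknown or untested is made for them only; others in the source may bear on it.

Cytotoxicity across the series is read in an ADME assay on HEL cells (Homo sapiens) for cytotoxicity; on this read-out lower numbers stand for higher toxicity in this test and higher numbers for lower toxicity in this test. Compound 1 `O=C(COc1cccc2ccccc12)N/N=C/C=C/c1ccccc1` gives 100 ug/mL, the highest of the two numbers obtained. Compound 3 `C/C(=N\NC(=O)COc1cccc2ccccc12)c1ccc(Br)cc1` gives 20 ug/mL, a step beyond the scatter under compound 1. Compound 2 `C/C(=N\NC(=O)COc1cccc2ccccc12)c1ccc(Cl)cc1` gives only a limit, >= 4 ug/mL. Accordingly a step that the limit leaves unreadable from compound 2 to compound 3 cannot be sized, the limit being (the limit of >= 4 ug/mL in this assay, at which 1 of the 3 values shown sits).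

Compound 4 `Cc1ccc(/C=N/NC(=O)COc2cccc3ccccc23)cc1` differs from compound 1 by 4-methylphenyl in place of 2-phenylethenyl on a carbon with a double bond to nitrogen. Among the compounds with values here, no measured step covers this exchange; the only recorded step, a step that the limit leaves unreadable from compound 2 to compound 3, concerns a halogen and is unreadable. Compounds 1 and 3 carry different groups on the carbon with a double bond to nitrogen and their numbers lie apart, so a change of moderate size in either direction is plausible. Compound 4 is expected at 50 ug/mL, within 15 ug/mL to 100 ug/mL. That corresponds to an expected step of a 2.0-fold lower number from compound 1 to compound 4 (0.30 log units; within the scatter).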

Compound 4, minimum cytotoxic concentration: 20 ug/mL
Compound 4: middle estimate off by 2.5-fold (0.40 log units), on the high side, within the range that was stated.
By their numbers in this assay, from the lowest: compounds 3 and 4 (each within the scatter of the next); then compound 1.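

Within the data shown here, on the carbon with a double bond to nitrogen, 4-methylphenyl in place of 2-phenylethenyl gives a 5.0-fold lower number from compound 1 to compound 4 (0.70 log units; beyond the scatter) in this assay and is the first readable step, so this position does affect the read-out. The exchange removes the double bond outside aromatic rings and adds a methyl-bearing phenyl, and this single step cannot separate the two changes. The data shown give no cause for the step.

From the compounds shown here alone, whether an amine or a carboxylic acid on the phenyl ring would move the number in either direction remains open. Going by these compounds, the effect of a longer chain in place of 2-phenylethenyl is also open.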